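The compounds below may be only part of what the source reports. "The series", "measured", "known", "first", "only" and "open" are said of these compounds alone.

Three compounds that share one core and differ only in the group on a single aromatic carbon have been measured in an in vitro ADME assay on microsomes from liver (Homo sapiens) for metabolic stability, with a stated time of 15 min; a lower number here means slower removal, a higher number faster removal of the compound. Compound 1 `COCc1cc(OC)c(-c2cccc3c(N(CC4CCOCC4)CC4CC4)c(C)nn23)c(OC)c1` gives 110 mL.min-1.g-1, compound 2 `COCc1cc(OC)c(-c2cccc3c(N(CC4CCOCC4)CC4CC4)c(C#N)nn23)c(OC)c1` gives 1100 mL.min-1.g-1, and compound 3 `CCc1nn2c(-c3c(OC)cc(COC)cc3OC)cccc2c1N(CC1CCOCC1)CC1CC1` gives 300 mL.min-1.g-1, so compound 3 holds the second highest of the three numbers. Compound 4 `COCc1cc(OC)c(-c2cccc3c(N(CC4CCOCC4)CC4CC4)c(OC)nn23)c(OC)c1` has not yet been measured. It differs from compound 3 by one change, methoxy in place of ethyl on an aromatic carbon.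

Within the data shown here, no measured step brings in methoxy, so the guide can only be the steps among the other groups at this carbon. The number rises in a 2.7-fold higher number from compound 1 to compound 3 (0.44 log units; beyond the scatter) and rises further in a 10-fold higher number from compound 1 to compound 2 (1.00 log units; beyond the scatter), while it falls in a 3.7-fold lower number from compound 2 to compound 3 (0.56 log units; beyond the scatter). All three steps lie beyond the scatter, so a swap here can clearly shift the number, but nothing measured shows which way methoxy would take it. With no direction to go on, the best starting point is the middle value of compound 3, 300 mL.min-1.g-1. The expected result is a 1.2-fold lower number from compound 3 to compound 4 (0.06 log units; within the scatter), a step no larger than the scatter. For compound 4 the estimated value is 260 mL.min-1.g-1, with an expected range from 100 mL.min-1.g-1 to 650 mL.min-1.g-1.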

Compound 4, intrinsic clearance in microsomes: 760 mL.min-1.g-1
Compound 4: middle estimate off by 2.9-fold (0.47 log units), on the low side; the measured number lies above the stated range.
By their numbers in this assay, from the lowest: compound 1; then compound 3; then compounds 4 and 2 (each within the scatter of the next).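

In this assay, the swap of ethyl for methoxy on this aromatic carbon is not a neutral one: the two groups have the same count of heavy atoms, yet the result is a 2.5-fold higher number from compound 3 to compound 4 (0.40 log units; beyond the scatter) and methoxy, unlike ethyl, carries a hydrogen-bond acceptor. Methoxy also falls level with cyano, since the step is a 1.4-fold lower number from compound 2 to compound 4 (0.16 log units; within the scatter) and the two cannot be told apart, while it stands well clear of methyl, with a 6.9-fold higher number from compound 1 to compound 4 (0.84 log units; beyond the scatter) as the step. The four groups at this carbon thus split into a lower pair, methyl and ethyl, which themselves differ beyond the scatter, and an upper pair, methoxy and cyano, which do not.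

Nothing given here explains why removal changes with these groups, or shows where on the molecules it takes place. On these data alone, it also remains open whether a plain hydrogen, a chlorine, a longer chain such as propyl, a larger ether such as ethoxy or an amine would join the lower pair or the upper pair.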